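Trading 3-(trifluoromethyl)phenyl for piperidin-1-yl

This account rests on a few compounds, and the source may have more. Where it says the series, first, only, none or still open, it means among the compounds named here.

Measured in an ADME assay on microsomes from liver (Homo sapiens) for metabolic stability, read by LC-MS, with a stated time of 30 min, tested at 1 uM; a higher number here means that more of the compound is left, a lower number that less of the compound is left:
- compound 1 `O=C(NCc1ccc(S(=O)(=O)N2CCCCC2)cc1)c1ccn2cncc2c1`: 54%
- compound 2 `O=C(NCc1ccc(S(=O)(=O)c2cccc(C(F)(F)F)c2)cc1)c1cc2ccncc2o1`: 48%

Compound 2 gives 48%, which lies within the usual scatter of compound 1 at 54%, so these two results cannot be told apart. The next molecule, compound 3 `O=C(NCc1ccc(S(=O)(=O)N2CCCCC2)cc1)c1cc2ccncc2o1`, keeps the rest of compound 2 but carries piperidin-1-yl in place of 3-(trifluoromethyl)phenyl on a sulfonyl sulfur. Among the measured compounds shown here, no measured pair shows this swap on its own, so any forecast is rough. Piperidin-1-yl is also present in compound 1, which gives 54%, so a large move in this assay is not expected. The expected change a number 3 percentage points higher from compound 2 to compound 3 (within the scatter) is slightly upward and no larger than the scatter. The estimate for compound 3 is 51%, with a range of 33% to 69%.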

Compound 3, percent of the compound remaining: 56%
Estimate against measurement, compound 3: 5 percentage points below; the measured number falls inside the stated range.
By their numbers in this assay, from the lowest: compounds 2, 1 and 3 (each within the scatter of the next).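

Replacing 3-(trifluoromethyl)phenyl with piperidin-1-yl on a sulfonyl sulfur, with the rest of the molecule unchanged, gives a number 8 percentage points higher from compound 2 to compound 3 (within the scatter) in this assay and shows that this position takes either ring without a change that can be read. The second single change, on a carbonyl carbon, gives a number 2 percentage points higher from compound 1 to compound 3 (within the scatter) and so the two groups at that place cannot be told apart in this assay either. Nothing available explains why these numbers lie so close together.

Every step shown stays within the scatter, so it remains open whether any change at these two places can move the number by more. A group such as dimethylamino or morpholin-4-yl on the sulfonyl sulfur could test this.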